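From 4-methoxyphenyl to 3-nitrophenyl on a shared core

This account rests on a few compounds, and the source may have more. Where it says the series, first, only, none or still open, it means among the compounds named here.

In an ADME assay on HEK293 cells (Homo sapiens) for cytotoxicity, read by MTT assay, with a stated time of 48 h (a higher number here means a weaker inhibitor, a lower number a stronger inhibitor), compound 1 `C=C1CCC[C@]2(C)CCC(C=O)=CC[C@@]12C` gives 734000 nM and compound 2 `C=C1CCC[C@]2(C)CCC(c3cn(-c4ccc(OC)cc4)nn3)=CC[C@@]12C` gives 410000 nM. These two numbers lie within the usual scatter of each other, so they cannot be told apart. Compound 3 `C=C1CCC[C@]2(C)CCC(c3cn(-c4cccc([N+](=O)[O-])c4)nn3)=CC[C@@]12C` is still unmeasured. It carries 3-nitrophenyl in place of 4-methoxyphenyl on an aromatic nitrogen. Among the measured compounds shown here, no measured pair shows what such a swap does, so no step beyond the scatter is expected in this assay. The estimated change is a 1.2-fold lower number from compound 2 to compound 3 (0.09 log units; within the scatter). For compound 3 the expected value is 330000 nM, with an estimated range of 110000 nM to 800000 nM.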

Compound 3, half-maximal inhibitory concentration: 699000 nM
The estimate for compound 3 lay 2.1-fold (0.33 log units) below the measured number; measured number inside the range.
By their numbers in this assay, from the lowest: compounds 2, 3 and 1 (each within the scatter of the next).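

In this assay, among the compounds shown here, the first measured swap at this aromatic nitrogen, 3-nitrophenyl in place of 4-methoxyphenyl, gives a 1.7-fold higher number from compound 2 to compound 3 (0.23 log units; within the scatter) and so cannot be told apart from repeat scatter. Between these two groups, then, this position shows no readable preference, although the groups differ in their substituent and in where it sits on the phenyl ring. No other measurement bears on this result. As far as these compounds go, whether a longer alkyl chain or a phenyl ring carrying an amine or a carboxylic acid on that nitrogen would give a step beyond the scatter remains open.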